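Lengthening the Side Chain on a Shared Core

This account rests on a few compounds, and the source may have more. Where it says the series, first, only, none or still open, it means among the compounds named here.

Compound 1 `CCCCCCCCc1cn([C@@H]2O[C@@H]3COP(=O)(O)O[C@H]3[C@H]2O)c(=O)nc1N` gives > 200 ug/mL in a functional assay on L1210 cells (Mus musculus) for cytotoxicity (a lower number here means a stronger inhibitor, a higher number a weaker inhibitor), which is a limit of the assay and not a number.
Compound 2 `Cc1cn([C@@H]2O[C@@H]3COP(=O)(O)O[C@H]3[C@H]2O)c(=O)nc1N` gives > 200 ug/mL in this assay, also only a limit.
Compound 3 `CCc1cn([C@@H]2O[C@@H]3COP(=O)(O)O[C@H]3[C@H]2O)c(=O)nc1N` gives > 200 ug/mL in this assay, again only a limit.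

Compound 3 therefore stands at the same limit as the other two values, as the limit of > 200 ug/mL in this assay, at which 3 of the 3 values shown sit, shows. Compound 4 `CCCCc1cn([C@@H]2O[C@@H]3COP(=O)(O)O[C@H]3[C@H]2O)c(=O)nc1N` differs from compound 3 by ethyl in place of hydrogen on a saturated chain carbon, two bonds along the chain from an aromatic carbon. The measured steps that bear on this change are a step that the two limits leave unreadable from compound 1 to compound 3 and a step that the two limits leave unreadable from compound 2 to compound 3; each runs between two limits, so no size can be read from either. Nothing in these numbers points to a move beyond the scatter, and compound 4 is expected to stay at the limit, a step that the limit leaves unreadable from compound 3 to compound 4. The estimate for compound 4 is 300 ug/mL, between 150 ug/mL and 1000 ug/mL.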

Compound 4, concentration for 50% inhibition: > 200 ug/mL
Compound 4 gave a limit, no number (the forecaster's own chance of this, stated with the estimate: 85%); the middle value is on the limit's open side.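

Within the data shown here, compound 4, like compound 1, compound 2 and compound 3, gives only a limit, and no step among them can be read: the limit of > 200 ug/mL in this assay, at which 4 of the 4 values shown sit.
On these data alone, what stays open is how far any of these side chains lies past that limit in this assay and whether their true values differ at all.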